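The source may hold more compounds than are shown below. What is called first, only, known or untested is meant among the compounds shown, and "the series" means these compounds.

Compound 1 `COc1cc(/C=C/C(=O)/C=C/c2cc(OC)c(OC)c(OC)c2)ccc1OCc1cn(CCOc2cc(=O)oc3ccccc23)nn1`: 22%
Compound 2 `COc1cc(/C=C/C(=O)/C=C/c2ccccc2)ccc1OCc1cn(CCOc2cc(=O)oc3ccccc23)nn1`: 10%

In a functional assay on PC-3 cells (Homo sapiens) for inhibition, read by sulforhodamine B assay, with a stated time of 48 h, tested at 50 uM (a higher number here means more inhibition of growth at the concentration tested, a lower number less inhibition of growth), compound 2 stands lowest of the two measured compounds, at 10%. Compound 3 `COc1ccccc1/C=C/C(=O)/C=C/c1ccc(OCc2cn(CCOc3cc(=O)oc4ccccc34)nn2)c(OC)c1` has not yet been measured and carries methoxy in place of hydrogen on an aromatic carbon, ortho to a large group: methoxy in place of hydrogen on an aromatic carbon. Going by the values given here, the only measured step that bears on this is a number 12 percentage points lower from compound 1 to compound 2 (beyond the scatter), a modest drop with phenyl in place of 3,4,5-trimethoxyphenyl. Restoring a single methoxy should therefore give, at most, a small rise in this assay, and the expected step is a number 4 percentage points higher from compound 2 to compound 3 (within the scatter). For compound 3 the estimated value is 14%, with an expected range of 5% to 26%.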

Compound 3, percent growth inhibition at one concentration: 11%
Compound 3: the middle estimate sits 3 percentage points above what was measured; measured number inside the range.
By their numbers in this assay, from the lowest: compounds 2 and 3 (each within the scatter of the next); then compound 1.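

In this assay, methoxy in place of hydrogen on an aromatic carbon, ortho to a large group, gives a number 1 percentage points higher from compound 2 to compound 3 (within the scatter) and so cannot be told apart from hydrogen at this place. With 2-methoxyphenyl in place of 3,4,5-trimethoxyphenyl there is still a number 11 percentage points lower from compound 1 to compound 3 (beyond the scatter) on the shared core, so this one methoxy does not recover the level of compound 1. No supporting evidence bears on this result.

The compounds shown leave open whether methoxy on another carbon of this ring would match compound 1. They also leave open whether an amine or a carboxylic acid at this place would move the number.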